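From Nitro to Methyl on a Shared Core

This account rests on a few compounds, and the source may have more. Where it says the series, first, only, none or still open, it means among the compounds named here.

Of the compounds shown here, three built on one shared core have numbers so far in a functional assay on HT-29 cells (Homo sapiens) for antiproliferative activity, read by MTT assay, with a stated time of 96 h; a higher number here means a weaker inhibitor, a lower number a stronger inhibitor. Compound 1 `CCCc1ccc(N2C(=O)NC3(CSC4=C3C(=O)c3ncccc3C4=O)C2=O)cc1` gives 1 nM. Compound 2 `O=C1NNC(=O)C2(CSC3=C2C(=O)c2ncccc2C3=O)N1` gives 1580 nM; 1600 nM; 1600 nM (3 entries), a set of repeats that agree closely with one another (the several entries of compound 2 in this assay, 1580 nM; 1600 nM; 1600 nM (3 entries)). For the measured compounds named here, compound 3 `O=C1C2=C(C(=O)c3ncccc31)C1(CS2)NC(=O)N(c2ccc([N+](=O)[O-])cc2)C1=O` gives 250 nM, the highest of the two single numbers, the nearest being compound 1 at a much lower number; the step of a 250-fold higher number from compound 1 to compound 3 (2.40 log units; beyond the scatter) is the only single-point change measured so far, and it is large and beyond the scatter.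

Compound 4 `Cc1ccc(N2C(=O)NC3(CSC4=C3C(=O)c3ncccc3C4=O)C2=O)cc1` has not yet been measured. It differs from compound 3 in one place: methyl in place of nitro on an aromatic carbon. The change sits on an aromatic carbon of a six-membered aromatic ring of carbon only, para to a large group. The measured step that bears on it is the one from propyl to nitro, which raised the number greatly; going back from nitro to methyl is expected to undo much of that rise. The expected step of a 50-fold lower number from compound 3 to compound 4 (1.70 log units; beyond the scatter) is therefore a large fall in this assay. Compound 4 is expected to give 5 nM, within a range from 1 nM to 40 nM.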

Compound 4, half-maximal inhibitory concentration: 1 nM
Beside the measured number, compound 4's estimate is 5.0-fold (0.70 log units) above it, within the range that was stated.
By their numbers in this assay, from the lowest: compounds 1 and 4 (each within the scatter of the next); then compound 3.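

In this assay, going from 4-nitrophenyl to 4-methylphenyl gives a 250-fold lower number from compound 3 to compound 4 (2.40 log units; beyond the scatter), so the rise seen earlier at this place on the aromatic ring is not tied to propyl alone: a different and much shorter chain also gives a far lower number than nitro does. For the compounds shown here, the comparison of the two alkyl groups adds something the earlier compounds could not show, with no change at the digits printed from compound 1 to compound 4 (within the scatter), which means that cutting the chain from propyl to methyl leaves the number unmoved at the digits printed, while nitro alone stands apart at this place. Going by these compounds alone, nothing measured so far explains why nitro differs so strongly from these two chains.

Nitro is the only group shown at this place that is not a plain carbon chain, so one compound carries the whole rise, and it stays open whether an amine, a carboxylic acid or a chlorine atom would follow nitro or the two chains. On these data alone, it also stays open whether a chain longer than propyl, or plain hydrogen at this place, would keep the number as low as methyl and propyl do.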